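The source may report more compounds than this note shows. Statements on the series, on what has been measured and on what is new or still open speak of the compounds shown alone.

Working notes on the series.

Compound 1 `CN1CCN(c2ccc(S(=O)(=O)Oc3cccc(F)c3)cc2)C1=O` gives 5800 nM in a functional assay on M21 cells (Homo sapiens) for antiproliferative activity, read by sulforhodamine B assay, with a stated time of 48 h; a higher number here means a weaker inhibitor, a lower number a stronger inhibitor. Compound 2 `CN1CCN(c2ccc(S(=O)(=O)Oc3cccc(Cl)c3)cc2)C1=O` differs by chloro in place of fluoro on an aromatic carbon and gives 1600 nM, a step of a 3.6-fold lower number from compound 1 to compound 2 (0.56 log units; beyond the scatter). Compound 3 `CCCN1CCN(c2ccc(S(=O)(=O)Oc3cccc(F)c3)cc2)C1=O` carries a second core, differing from compound 1 by ethyl in place of hydrogen on a saturated chain carbon bound to an amide-type nitrogen in a ring; in this assay compound 3 gives 12000 nM, a step of a 2.1-fold higher number from compound 1 to compound 3 (0.32 log units; beyond the scatter). Compound 4 `CCCN1CCN(c2ccc(S(=O)(=O)Oc3cccc(Cl)c3)cc2)C1=O`, not yet measured, differs from compound 3 by chloro in place of fluoro on an aromatic carbon, the same change as from compound 1 to compound 2, at the same place. Within the data shown here, compound 4 is expected to show a step of about a 3.5-fold lower number from compound 3 to compound 4 (0.55 log units; beyond the scatter), resting on the single earlier instance a 3.6-fold lower number from compound 1 to compound 2 (0.56 log units; beyond the scatter) and on compound 3 at 12000 nM. Compound 4 is thus estimated at 3400 nM, with a range of 1500 nM to 8000 nM.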

Compound 4, half-maximal inhibitory concentration: 8600 nM
Beside the measured number, compound 4's estimate is 2.5-fold (0.40 log units) below it; the measured number lies above the stated range.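

In this assay, chloro in place of fluoro gives a 1.4-fold lower number from compound 3 to compound 4 (0.14 log units; within the scatter), and its two instances do not differ beyond what two such steps allow: the same change on two cores in this assay, a 3.6-fold lower number (0.56 log units; beyond the scatter) from compound 1 to compound 2 and a 1.4-fold lower number (0.14 log units; within the scatter) from compound 3 to compound 4, 2.6-fold (0.41 log units) apart, within the scatter of two such steps. Ethyl in place of hydrogen gives a 5.4-fold higher number from compound 2 to compound 4 (0.73 log units; beyond the scatter), and it too carries between the cores within that allowance: the same change on two cores in this assay, a 2.1-fold higher number (0.32 log units; beyond the scatter) from compound 1 to compound 3 and a 5.4-fold higher number (0.73 log units; beyond the scatter) from compound 2 to compound 4, 2.6-fold (0.41 log units) apart, within the scatter of two such steps. This shows no sign that either change depends on the core, but two pairs cannot fix a common size for either change, and the chloro step on the core of compound 3 does not by itself separate chloro from fluoro.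

Going by these compounds, whether bromo, methoxy or trifluoromethyl at the same aromatic carbon would follow the same course remains open. So does the effect of a longer chain or a benzyl group on the amide-type nitrogen.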